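Removing the aryl amide for an ethyl oxamate ester

A few compounds are considered here, and "the series" means these few. Any claim that something is new, unique, unknown or untested is made for them only; others in the source may bear on it.

Within the data shown here, compound 1 `COc1cc(/C=C/C(=O)c2cccc(NC(=O)c3ccc(Cl)cc3)c2)ccc1O` stands highest of the two numbers so far in a functional assay on HUVEC cells (Homo sapiens) for inhibition (on this read-out lower numbers stand for stronger inhibition and higher numbers for weaker inhibition), where compound 1 gives 0.76 ug/mL; compound 2 `COc1cc(/C=C/C(=O)c2cccc(NC(=O)c3ccc(Cl)cc3Cl)c2)ccc1O` gives 0.4 ug/mL, and the one step, a 1.9-fold lower number from compound 1 to compound 2 (0.28 log units; within the scatter), is a minor change. Compound 3 `CCOC(=O)C(=O)Nc1cccc(C(=O)/C=C/c2ccc(O)c(OC)c2)c1` differs from compound 1 by ethoxycarbonyl in place of 4-chlorophenyl on a carbonyl carbon. Among the measured compounds shown here, no measured step alters this part of the molecule, so the chloro step gives no direct guide; the change is a large one, and a weaker inhibition is expected. The estimate for compound 3 is 2 ug/mL (range 0.6 ug/mL to 8 ug/mL), a step of a 2.6-fold higher number from compound 1 to compound 3 (0.42 log units; beyond the scatter).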

Compound 3, half-maximal inhibitory concentration: 13.3 ug/mL
Estimate against measurement, compound 3: 6.7-fold (0.82 log units) below; measured number outside the range, above it.
By their numbers in this assay, from the lowest: compounds 2 and 1 (each within the scatter of the next); then compound 3.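

In this assay ethoxycarbonyl on the carbonyl carbon gives an 18-fold higher number from compound 1 to compound 3 (1.24 log units; beyond the scatter) and a 33-fold higher number from compound 2 to compound 3 (1.52 log units; beyond the scatter) and so weighs far more than the chloro step. The substituent on this carbonyl therefore matters strongly to the read-out, which the two chlorinated aryl amides could not show alone. No evidence on the cause of this loss is at hand.

The compounds shown leave open whether the loss follows from removing the aromatic ring or from bringing in the ester. An unsubstituted phenyl, an ethyl group or a carboxylic acid at this carbonyl would separate the two.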